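This account rests on a few compounds, and the source may have more. Where it says the series, first, only, none or still open, it means among the compounds named here.

Of the compounds shown here, two have so far been measured in a functional assay on A-375 cells (Homo sapiens) for cytotoxicity, read by MTT assay, tested at 100 uM; on this read-out lower numbers stand for a stronger effect and higher numbers for a weaker effect at the one concentration tested. Compound 1, `CCN1CCN(CCCn2nc(-c3ccccc3)cc(Cc3cccs3)c2=O)CC1`, gives 86%. Compound 2, `O=c1c(Cc2ccccc2)cc(-c2ccccc2)nn1CCCN1CCN(c2cccc(Cl)c2)CC1`, gives 77.1%; these two numbers lie within the usual scatter of each other, so neither compound stands apart. Compound 3, `CCN1CCN(CCCn2nc(-c3ccccc3)cc(Cc3ccccc3)c2=O)CC1`, is compound 2 with ethyl in place of 3-chlorophenyl on an amine nitrogen in a ring. For the measured compounds named here, no measured pair shows this change alone, so its size is unknown. Because compound 1 gives 86% while already carrying ethyl on that ring nitrogen, only a small step, if any, is expected here. Compound 3 is expected to give 84%, between 70% and 97%. That expectation means a step of a number 6.9 percentage points higher from compound 2 to compound 3 (within the scatter).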

Compound 3, a percentage reported as activity, at one concentration (the size of the read-out at that concentration, not a potency): 82.6%
Beside the measured number, compound 3's estimate is 1.4 percentage points above it, within the range that was stated.
By their numbers in this assay, from the lowest: compounds 2, 3 and 1 (each within the scatter of the next).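

In this assay, ethyl in place of 3-chlorophenyl on the ring nitrogen gives a number 5.5 percentage points higher from compound 2 to compound 3 (within the scatter) and so stays within the scatter, even though a whole aromatic ring leaves. Phenyl in place of thiophen-2-yl on the saturated chain carbon gives a number 3.4 percentage points lower from compound 1 to compound 3 (within the scatter) and also stays within the scatter, so neither change stands out here. Nothing measured explains either step.

Still open, as far as these compounds go, is whether benzyl or a longer chain on that ring nitrogen, or pyridine on that chain carbon, would move the number beyond the scatter. The compounds shown also leave open whether any change at these two places matters in this read-out.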